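Amide nitrogen substituent series: from methyl to allyl

The source may hold more compounds than are shown below. What is called first, only, known or untested is meant among the compounds shown, and "the series" means these compounds.

Measured compounds:
compound 1, `CCN(Cc1cccs1)C(=O)COc1ccc(C)cc1`, 8 nM
compound 2, `CCC(C)N(Cc1cccs1)C(=O)COc1ccc(C)cc1`, 2000 nM
compound 3, `Cc1ccc(OCC(=O)N(C)Cc2cccs2)cc1`, 400 nM

All three share the same core and differ only in the group on the amide-type nitrogen. In an assay on HEK293 cells for agonist activity at transient receptor potential cation channel subfamily M member 8 (Homo sapiens), read by fluorescence and calcium flux, with a stated time of 15 min (on this read-out higher numbers stand for an effect only at larger amounts of compound and lower numbers for an effect already at smaller amounts), compound 1 gives 8 nM, the lowest value of the set. Compound 3 stands second highest of the three values: compound 2 is nearest, a 5.0-fold lower number from compound 2 to compound 3 (0.70 log units; beyond the scatter), while compound 1 is furthest, a 50-fold higher number from compound 1 to compound 3 (1.70 log units; beyond the scatter).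

The next compound, compound 4, `C=CCN(Cc1cccs1)C(=O)COc1ccc(C)cc1`, is to be measured in this assay. Against compound 3 the change is vinyl in place of hydrogen on a saturated chain carbon bound to an amide-type nitrogen.

Going by the values given here, two measured steps bear on this. Growing the chain from hydrogen to methyl at the same place, read in reverse of a 50-fold higher number from compound 1 to compound 3 (1.70 log units; beyond the scatter), brought a large drop in the number. Growing it further, a 250-fold higher number from compound 1 to compound 2 (2.40 log units; beyond the scatter), brought a large rise. Allyl is larger than ethyl but smaller than sec-butyl, so the step is expected to fall between these two outcomes: a lower number than compound 3, though not necessarily reaching compound 1. For compound 4 the expected step is a 10-fold lower number from compound 3 to compound 4 (1.00 log units; beyond the scatter). Compound 4 is thus estimated at 40 nM, with a range from 8 nM to 300 nM.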

Compound 4, half-maximal effective concentration: 20 nM
Beside the measured number, compound 4's estimate is 2.0-fold (0.30 log units) above it; measured number inside the range.
By their numbers in this assay, from the lowest: compound 1; then compound 4; then compound 3; then compound 2.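

In this assay, the allyl group on the amide-type nitrogen lands close to the ethyl of compound 1 rather than near the methyl or sec-butyl compounds: a 20-fold lower number from compound 3 to compound 4 (1.30 log units; beyond the scatter), and a 100-fold lower number from compound 2 to compound 4 (2.00 log units; beyond the scatter). Going by these compounds alone, the earlier compounds allowed the reading that anything larger than ethyl sends the number steeply up, but compound 4 shows that a group extending one carbon further, and carrying a double bond, can keep it low, so the order of the four compounds does not simply follow group size, with compound 2 as the only one far above compound 1 on the larger side. Ethyl still holds the lowest value, though the margin is now much narrower, a 2.5-fold higher number from compound 1 to compound 4 (0.40 log units; beyond the scatter), and no measurement at hand accounts for any of these steps.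

Going by these compounds, what remains open is whether the low number of compound 4 depends on the double bond or on the chain alone, which propyl on the amide-type nitrogen would separate. Also open, on these data alone, is whether the high number of compound 2 goes with branching or with size, a question that isopropyl and a longer chain such as butyl could address.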